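Halogen swap on the aryl ketone of compound 1

The source may hold more compounds than are shown below. What is called first, only, known or untested is meant among the compounds shown, and "the series" means these compounds.

Measured in a functional assay on Malme-3M cells (Homo sapiens) for inhibition, read by sulforhodamine B assay, with a stated time of 48 h (on this read-out higher numbers stand for weaker inhibition of growth and lower numbers for stronger inhibition of growth), so far:
Compound 1, `COc1cc(-c2cc(/C=C/C(=O)c3ccc(Cl)c(Cl)c3)[nH]n2)cc(OC)c1OC`: compound 1 gives > 100000 nM, a limit of the assay and not a number.
Compound 2, `COc1ccc(-c2cc(/C=C/C(=O)c3ccc(N)cc3)[nH]n2)cc1OC`: compound 2 gives 21200 nM.
Compound 3, `COc1cc(C(=O)/C=C/c2cc(-c3cc(OC)c(OC)c(OC)c3)n[nH]2)cc(OC)c1OC`: compound 3 gives 4090 nM.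

Going by these compounds, compound 1 sits at the limit of > 100000 nM in this assay, at which 1 of the 3 values shown sits, so its true position is unknown beyond that boundary. Compounds 2 and 3 each give a number, and they differ from compound 1 in more than one place, so no single step can be read between any two of the measured compounds.

Compound 4, `COc1cc(-c2cc(/C=C/C(=O)c3ccc(F)c(F)c3)[nH]n2)cc(OC)c1OC`, has not yet been measured. Its relation to compound 1 is 3,4-difluorophenyl in place of 3,4-dichlorophenyl on a carbonyl carbon. The change keeps the ring size and the count of heavy atoms, donors and acceptors, and only the halogen pair is exchanged. For the measured compounds named here, no measured pair in this set shows what such an exchange does in this assay, so the expected step of an at least 1.2-fold lower number from compound 1 to compound 4 (0.09 log units; that floor lies within the scatter) is taken as small, with compound 1 at a limit leaving the direction open. On that basis compound 4 is expected to give 80000 nM, between 20000 nM and 300000 nM, with a real chance that only a limit is reported.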

Compound 4, concentration for total growth inhibition: 9400 nM
The estimate for compound 4 lay 8.5-fold (0.93 log units) above the measured number; the whole stated range lies above it.
By their numbers in this assay, from the lowest: compound 3; then compound 4; then compound 2. At a limit, above all of these: compound 1.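

In this assay, 3,4-difluorophenyl in place of 3,4-dichlorophenyl on a carbonyl carbon gives an at least 10-fold lower number from compound 1 to compound 4 (1.02 log units; beyond the scatter). For the compounds shown here, this is the first step that can be read at a single place, and it shows that the read-out responds to the halogen pair on the aryl ketone alone, with the shared core, the ring size and the counts of heavy atoms, donors and acceptors unchanged. The value of compound 1, > 100000 nM, is a limit and not a number, so the step fixes only a minimum size and its full size stays unknown: the limit of > 100000 nM in this assay, at which 1 of the 4 values shown sits.

Steps from compound 4 to compound 2 or compound 3 cannot be read, as these compounds differ in more than one place, so the contribution of the other aryl ketone groups and of the methoxy pattern on the far ring stays unresolved. Also open, going by these compounds, is how the number would respond to a single fluorine, a trifluoromethyl group, a nitrile or a dimethylamino group in place of the halogen pair on the aryl ketone.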